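Pyridin-3-yl to pyridin-4-yl: expected growth inhibition shift

The source may report more compounds than this note shows. Statements on the series, on what has been measured and on what is new or still open speak of the compounds shown alone.

Of the compounds shown here, two have been measured in a functional assay on prostate cells (Homo sapiens) for antiproliferative activity; on this read-out lower numbers stand for stronger inhibition of growth and higher numbers for weaker inhibition of growth. Compound 1 `N=C(N)N/N=C/c1c(-c2ccccn2)nc2sc(Cl)cn12` gives 17800 nM in this assay. Compound 2 `Cc1cn2c(/C=N/NC(=N)N)c(-c3cccnc3)nc2s1` gives 24500 nM in this assay. The two numbers lie within the usual scatter of each other, so compound 2 stands together with compound 1 and neither can be set apart as stronger or weaker on this evidence. Among the measured compounds shown here, no step between measured compounds that differ in a single place is available, and the two measured compounds differ in more than one place.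

Compound 3 `Cc1cn2c(/C=N/NC(=N)N)c(-c3ccncc3)nc2s1` is the next point. It differs from compound 2 as follows: pyridin-4-yl in place of pyridin-3-yl on an aromatic carbon. The change rearranges the same atoms and keeps donor and acceptor counts unchanged, and nothing measured in the series speaks to its effect. The expectation for this assay is therefore a step of a 1.1-fold lower number from compound 2 to compound 3 (0.05 log units; within the scatter), that is no movement beyond the scatter. Compound 3 is expected to give about 22000 nM in this assay, with a range from 8000 nM to 60000 nM.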

Compound 3, concentration for total growth inhibition: 32400 nM
For compound 3 the middle estimate is 1.5-fold (0.17 log units) below the measured one; the measured number falls inside the stated range.
By their numbers in this assay, from the lowest: compounds 1, 2 and 3 (each within the scatter of the next).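

In this assay, among the compounds shown here, the swap of pyridin-3-yl for pyridin-4-yl gives a 1.3-fold higher number from compound 2 to compound 3 (0.12 log units; within the scatter) and provides the first step that can be read at a single place. On this aromatic carbon of a five-membered aromatic ring with 2 nitrogen, the two pyridine isomers therefore cannot be told apart on this read-out, so relocating the ring nitrogen within the attached ring has no resolved effect here, though this rests on a single pair. No separate measurement bears on this step, and the result stands as an observation alone.

The compounds shown leave open whether a phenyl ring, a piperidine ring or a pyridine carrying an amine or a carboxylic acid at this position would give a step beyond the scatter. From the compounds shown here alone, compound 1 differs from both compound 2 and compound 3 in more than one place, so the separate contributions of its attached ring and its chlorine, set against the methyl of the other two, also remain open.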